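Arylsulfanylmethyl purine ribosides: the iodophenyl analogue

The source may hold more compounds than are shown below. What is called first, only, known or untested is meant among the compounds shown, and "the series" means these compounds.

In an assay on isolated protein for binding affinity to Equilibrative nucleoside transporter 1 (Homo sapiens) (a higher number here means a weaker inhibitor, a lower number a stronger inhibitor), compound 1 `CCSc1ncnc2c1ncn2[C@@H]1O[C@H](CO)[C@@H](O)[C@H]1O` gives 57500 nM, compound 2 `OC[C@H]1O[C@@H](n2cnc3c(CSc4ccccc4Cl)ncnc32)[C@H](O)[C@@H]1O` gives 1780 nM, and compound 3 `OC[C@H]1O[C@@H](n2cnc3c(CSc4ccc(Cl)c(Cl)c4)ncnc32)[C@H](O)[C@@H]1O` gives 224 nM, the lowest of the three numbers; its nearest neighbour is compound 2. The two steps are a 32-fold lower number from compound 1 to compound 2 (1.51 log units; beyond the scatter) and a 7.9-fold lower number from compound 2 to compound 3 (0.90 log units; beyond the scatter), both beyond the scatter.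

Compound 4 `OC[C@H]1O[C@@H](n2cnc3c(CSc4ccc(I)cc4)ncnc32)[C@H](O)[C@@H]1O` differs from compound 3 by 4-iodophenyl in place of 3,4-dichlorophenyl on a sulfur. Within the data shown here, only the step from compound 2 to compound 3 bears on this, and it concerns a change in the phenyl substitution pattern, not a halogen exchange. A single iodine replacing two chlorines is expected to leave the number near that of compound 3, within the scatter, so a 1.3-fold higher number from compound 3 to compound 4 (0.13 log units; within the scatter) is the estimated step. For compound 4 the expected value is 300 nM, between 90 nM and 1000 nM.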

Compound 4, half-maximal inhibitory concentration: 69.2 nM
Compound 4: middle estimate off by 4.3-fold (0.64 log units), on the high side; the whole stated range lies above it.
By their numbers in this assay, from the lowest: compound 4; then compound 3; then compound 2; then compound 1.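

In this assay 4-iodophenyl in place of 3,4-dichlorophenyl on the sulfur gives a 3.2-fold lower number from compound 3 to compound 4 (0.51 log units; beyond the scatter) and shows that the aryl group still moves the number beyond the scatter after compound 3. Against 2-chlorophenyl the same group gives a 26-fold lower number from compound 2 to compound 4 (1.41 log units; beyond the scatter) and the full change from ethylsulfanyl gives an 830-fold lower number from compound 1 to compound 4 (2.92 log units; beyond the scatter) which leaves compound 4 lowest of the four. Nothing available accounts for this gain.

Compound 4 changes the halogen and its pattern together, and 4-chlorophenyl or 4-bromophenyl would separate the two. Going by these compounds, how an amine or a carboxylic acid on that phenyl would read remains open.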